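One Amine Swap and a Cytotoxicity Question

This account rests on a few compounds, and the source may have more. Where it says the series, first, only, none or still open, it means among the compounds named here.

Of the compounds shown here, two have so far been tested in an ADME assay on L6 cells (Rattus norvegicus) for cytotoxicity; on this read-out higher numbers stand for weaker inhibition and lower numbers for stronger inhibition. Compound 1 `COc1ccc(C2CC3(N(C)C)CC(O)C2C(c2ccc(OC)cc2)C3)cc1` gives 63400 nM. Compound 2 `CN(C)C12C/C(=N\O)C(C(c3ccc(Cl)cc3)C1)C(c1ccc(Cl)cc1)C2` gives 7820 nM, the lower of the two numbers, and the gap between them lies beyond the usual scatter. These two compounds differ in more than one place, and their gap cannot be pinned on any single change.

Compound 3 `O/N=C1\CC2(N3CCCC3)CC(c3ccc(Cl)cc3)C1C(c1ccc(Cl)cc1)C2` has not yet been measured. It departs from compound 2 in one place, with pyrrolidin-1-yl in place of dimethylamino on a saturated ring carbon. Within the data shown here, no measured pair shows this swap, and the data favour no direction. The expected change, a 1.2-fold lower number from compound 2 to compound 3 (0.08 log units; within the scatter), is no step beyond the scatter in this assay. For compound 3 the estimated value is 6500 nM, with an expected range from 2500 nM to 17000 nM.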

Compound 3, half-maximal inhibitory concentration: 12700 nM
The estimate for compound 3 lay 2.0-fold (0.29 log units) below the measured number; low and high end bracket the measured number.
By their numbers in this assay, from the lowest: compounds 2 and 3 (each within the scatter of the next); then compound 1.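

Among these compounds, this is the first pair in this assay that differs in one place, so pyrrolidin-1-yl in place of dimethylamino on a saturated ring carbon can now be read on its own (a 1.6-fold higher number from compound 2 to compound 3 (0.21 log units; within the scatter)). The step stays within the scatter, so closing the amine into a five-membered ring gives no measurable difference on this read-out, and at this position the two groups cannot be told apart. No supporting measurement speaks to why the two groups read alike.

As far as these compounds go, whether a piperidin-1-yl group, a morpholin-4-yl group or an unsubstituted amine on the same ring carbon would also stay within the scatter remains open. Also open, from the compounds shown here alone, is whether this swap would read the same on the core of compound 1.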